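The source may hold more compounds than are shown below. What is called first, only, known or untested is meant among the compounds shown, and "the series" means these compounds.

Measured so far in a functional assay on HepG2 cells (Homo sapiens) for inhibition, read by MTT assay, with a stated time of 72 h; a higher number here means a weaker inhibitor, a lower number a stronger inhibitor:
compound 1 `CC1=C(C(C)CC(=O)OCC(C)COc2no[n+]([O-])c2S(=O)(=O)c2ccccc2)C(=O)c2c(O)cccc2C1=O`: 3740 nM
compound 2 `CC1=C(CCCC(=O)OCCOc2no[n+]([O-])c2S(=O)(=O)c2ccccc2)C(=O)c2c(O)cccc2C1=O`: 4160 nM

Compound 1 gives the lower of the two numbers in this assay, but compound 2 sits within the scatter of it, so the two are not separated. Compound 3 `CC1=C(C(C)CC(=O)OCCCOc2no[n+]([O-])c2S(=O)(=O)c2ccccc2)C(=O)c2c(O)cccc2C1=O` differs from compound 1 by hydrogen in place of methyl on a saturated chain carbon bound to two saturated chain carbons. Going by the values given here, no measured pair shows a step of this kind, so there is nothing to lean on. In this assay the change is expected to be small, none beyond the scatter. Compound 3 is therefore estimated at 4000 nM, with a range from 1900 nM to 8500 nM. The expected step is a 1.1-fold higher number from compound 1 to compound 3 (0.03 log units; within the scatter).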

Compound 3, half-maximal inhibitory concentration: 4320 nM
The estimate for compound 3 lay 1.1-fold (0.03 log units) below the measured number; the range from low to high includes it.
By their numbers in this assay, from the lowest: compounds 1, 2 and 3 (each within the scatter of the next).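

In this assay, going by these compounds alone, hydrogen in place of methyl on a saturated chain carbon bound to two saturated chain carbons gives a 1.2-fold higher number from compound 1 to compound 3 (0.06 log units; within the scatter) as the first measured step at this position. This methyl can thus be exchanged for hydrogen here without separating the two compounds in this read-out. No evidence at hand explains this result. The compounds shown leave open whether a longer chain, a hydroxyl group or an amine on this carbon would move the number beyond the scatter.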